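Acyl in place of aryl on the ring nitrogen of compound 2

The source may hold more compounds than are shown below. What is called first, only, known or untested is meant among the compounds shown, and "the series" means these compounds.

Measured compounds in an assay on HeLa cells for inhibition of Indoleamine 2,3-dioxygenase 1 (Homo sapiens); on this read-out lower numbers stand for stronger inhibition and higher numbers for weaker inhibition:
- compound 1 `Cc1nccc(N2CCc3nc(C4(C(=O)Nc5ccc(F)cc5)CCC4)ccc32)n1`: 21 nM
- compound 2 `O=C(Nc1ccc(F)cc1)C1(c2ccc3c(n2)CCN3c2ccccn2)CCC1`: 10.9 nM
- compound 3 `Cc1nccc(N2c3ccc(C4(NC(=O)c5ccc(F)cc5)CC4)cc3[C@H]3CC[C@H]32)n1`: 3.8 nM

Among these three numbers compound 2 stands second highest. Its nearest neighbour is compound 1, and the pair differ by a 1.9-fold lower number from compound 1 to compound 2 (0.28 log units; within the scatter), so the two are not separated on this read-out. Compound 3, which has a different core, gives 3.8 nM and lies furthest from compound 2.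

Compound 4 `O=C(c1cccc(Cl)c1)N1CCc2nc(C3(C(=O)Nc4ccc(F)cc4)CCC3)ccc21` differs from compound 2 at the same nitrogen touched in the step from compound 1 to compound 2: (3-chlorophenyl)carbonyl in place of pyridin-2-yl on a nitrogen on an aromatic ring in a ring

Within the data shown here, the only step that bears on this position is the one from compound 1 to compound 2, which exchanged one six-membered aromatic ring for another and stayed within the scatter. Among the measured compounds shown here, no measured pair shows an exchange of an aryl for an acyl group at this nitrogen, so the direction of any effect is not anchored by data. In this assay the step from compound 2 to compound 4 is therefore expected to be a 1.7-fold higher number from compound 2 to compound 4 (0.22 log units; within the scatter), with a wide range around it. Compound 4 is expected to give 18 nM, estimated between 4 nM and 80 nM.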

Compound 4, half-maximal inhibitory concentration: 3 nM
The estimate for compound 4 lay 6.0-fold (0.78 log units) above the measured number; measured number outside the range, below it.
By their numbers in this assay, from the lowest: compounds 4 and 3 (each within the scatter of the next); then compounds 2 and 1 (each within the scatter of the next).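

In this assay the ring nitrogen tolerates more than a directly attached aromatic ring: with (3-chlorophenyl)carbonyl there, the read-out shows a 3.6-fold lower number from compound 2 to compound 4 (0.56 log units; beyond the scatter) and a 7.0-fold lower number from compound 1 to compound 4 (0.85 log units; beyond the scatter) on the same core. The earlier exchange of 2-methylpyrimidin-4-yl for pyridin-2-yl, a 1.9-fold lower number from compound 1 to compound 2 (0.28 log units; within the scatter), gave no separation, so this is the first change at this nitrogen shown to move the number beyond the scatter. No measurement on these compounds accounts for the shift.

The change brings in a carbonyl and a chlorine together, and the compounds shown do not separate their contributions; a plain benzoyl or an acetyl group on this nitrogen would bear on that. Also open, as far as these compounds go, is how a sulfonyl link in place of the carbonyl would read in this assay.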